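Methyl to Bromo in Compound 2

The source may report more compounds than this note shows. Statements on the series, on what has been measured and on what is new or still open speak of the compounds shown alone.

In an ADME assay on BHK-21 cells (Mesocricetus auratus) for cytotoxicity, read by MTT assay, with a stated time of 72 h (on this read-out lower numbers stand for higher toxicity in this test and higher numbers for lower toxicity in this test), compound 1 `Cc1ccc(NCc2cn(-c3ccccc3)nc2-c2ccc(Cl)cc2)cc1` gives > 100000 nM, which is a limit of the assay. Compound 3 `Cc1ccc(NCc2cn(-c3ccccc3)nc2-c2ccc(Br)cc2)cc1` gives > 100000 nM, likewise a limit. Within the data shown here, compound 2 `Cc1ccc(NCc2cn(-c3ccccc3)nc2-c2ccc(C(F)(F)F)cc2)cc1` gives 88000 nM, the only actual number among the three.

Compound 4 `FC(F)(F)c1ccc(-c2nn(-c3ccccc3)cc2CNc2ccc(Br)cc2)cc1` departs from compound 2 by a single change, (bromo in place of methyl on an aromatic carbon), with (4-methylphenyl)amino becoming (4-bromophenyl)amino. Among the measured compounds shown here, none of the measured steps exchanges methyl for bromo. They exchange chloro, bromo and trifluoromethyl instead, and offer only indirect guidance. Trifluoromethyl in place of chloro gives an at least 1.1-fold lower number from compound 1 to compound 2 (0.05 log units; that floor lies within the scatter), and bromo in place of trifluoromethyl gives an at least 1.1-fold higher number from compound 2 to compound 3 (0.05 log units; that floor lies within the scatter). Bromo in place of chloro gives a step that the two limits leave unreadable from compound 1 to compound 3. With no measured step beyond the scatter, the estimate is for no real shift, and the expected step is a 1.0-fold lower number from compound 2 to compound 4 (0.02 log units; within the scatter). A report as a limit would not be unexpected. Compound 4 is expected at 85000 nM, with an estimated range of 40000 nM to 140000 nM.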

Compound 4, half-maximal cytotoxic concentration: 28000 nM
Compound 4: middle estimate off by 3.0-fold (0.48 log units), on the high side; the measured number lies below the stated range.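

In this assay, bromo in place of methyl, para to a large group, gives a 3.1-fold lower number from compound 2 to compound 4 (0.50 log units; beyond the scatter), the only step shown that lies beyond the scatter. This shows that the number responds to a change at this position, with the lower number standing for higher toxicity in this test, and that the change involves one heavy atom leaving and one entering. The earlier steps, all made elsewhere in the molecule, could not show this because none has a size that can be read beyond the scatter: the limit of > 100000 nM in this assay, at which 2 of the 4 values shown sit.

Only methyl and bromo are shown at this position, so it remains open how chloro, an amine or a carboxylic acid there would read. As far as these compounds go, it also remains open whether the exchange would give a step of similar size with chloro or bromo in place of the trifluoromethyl group.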